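Replacing an amide with a urea on a shared core

The compounds below may be only part of what the source reports. "The series", "measured", "known", "first", "only" and "open" are said of these compounds alone.

Measured compounds:
Compound 1, `CNC(=O)c1cc(Oc2ccc3nc(NC(=O)c4ccc(Cl)cc4)sc3c2)ccn1`: 83%
Compound 2, `CNC(=O)c1cc(Oc2ccc3nc(NC(=O)c4cccc(F)n4)sc3c2)ccn1`: 89.4%

Both compounds were tested in a functional assay on SK-BR-3 cells (Homo sapiens) for inhibition, read by MTT assay, with a stated time of 2 days, tested at 100 uM; a higher number here means more inhibition of growth at the concentration tested, a lower number less inhibition of growth. Compound 1 gives 83% and compound 2 gives 89.4%. The two numbers cannot be told apart, since a number 6.4 percentage points higher from compound 1 to compound 2 (within the scatter); compound 2 therefore stands on a level with compound 1 rather than apart from it.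

Compound 3, `CNC(=O)c1cc(Oc2ccc3nc(NC(=O)Nc4ccc(F)cc4)sc3c2)ccn1`, is not yet measured. It differs from compound 2 in one place: (4-fluorophenyl)amino in place of 6-fluoropyridin-2-yl on a carbonyl carbon. In plainer terms, the amide of compound 2 becomes a urea in compound 3, with a fluorine-bearing phenyl ring on the new nitrogen.

For the measured compounds named here, only one measured step touches this part of the molecule, the exchange of the aryl group on the same carbonyl carbon, and it gave a number 6.4 percentage points higher from compound 1 to compound 2 (within the scatter). Going by the values given here, no measured step adds an amino group there, so the effect of the urea itself is unknown. On that basis, compound 3 is expected to stay close to compound 2, with an expected change of a number 4.4 percentage points lower from compound 2 to compound 3 (within the scatter) and no step beyond the scatter. Compound 3 is estimated at 85%, within a range from 65% to 97%.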

Compound 3, percent growth inhibition at one concentration: 72.9%
The estimate for compound 3 lay 12.1 percentage points above the measured number; low and high end bracket the measured number.
By their numbers in this assay, from the lowest: compound 3; then compounds 1 and 2 (each within the scatter of the next).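

For the compounds shown here, at this carbonyl carbon, exchanging one aryl group for another had left the number within the scatter, but in this assay the urea gives the first steps beyond it: a number 16.5 percentage points lower from compound 2 to compound 3 (beyond the scatter) and a number 10.1 percentage points lower from compound 1 to compound 3 (beyond the scatter) in the second comparison. The position is therefore not indifferent to every change, although both steps are modest and compound 3 still gives 72.9% at the single concentration tested. Nothing measured here accounts for the drop.

Compound 3 gains the urea nitrogen and replaces the ring in one step, so the compounds shown cannot separate the contribution of the nitrogen from that of the ring, and a urea carrying 6-fluoropyridin-2-yl on the new nitrogen would be the direct test. On these data alone, it also remains open how this carbonyl carbon would respond to a group without an aromatic ring, such as cyclohexylamino or dimethylamino, and whether the lower number would hold at other concentrations.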